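One stereocentre inverted, exposure still to be measured

The compounds below may be only part of what the source reports. "The series", "measured", "known", "first", "only" and "open" are said of these compounds alone.

Measured in an ADME assay on the whole organism (plasma, strain Sprague-Dawley) for pharmacokinetics, with Rattus norvegicus as the target, at a dose of 1 mg/kg by the oral route; on this read-out lower numbers stand for lower exposure and higher numbers for higher exposure at the dose given:
- compound 1 `CNc1c(-c2ccc(=O)n(-c3ccccc3C)n2)c(-c2ccc(F)cc2)nn1C`: 235 ng.h/mL
- compound 2 `Cc1ccccc1-n1nc(-c2c(-c3ccc(F)cc3)nn3c2NC[C@@H](O)C3)ccc1=O`: 763 ng.h/mL

Of these two numbers, the higher belongs to compound 2, at 763 ng.h/mL, and its gap to compound 1, at 235 ng.h/mL, lies beyond the usual scatter. Compound 3 `Cc1ccccc1-n1nc(-c2c(-c3ccc(F)cc3)nn3c2NC[C@H](O)C3)ccc1=O` has not yet been measured. It has the same atoms and bonds as compound 2, and the two differ only in configuration: the two compounds have the same atoms and bonds and differ only in configuration as drawn: 1 of 1 stereo elements differ; a stereocentre at a saturated ring carbon is drawn R in compound 2 and S in compound 3. The two measured compounds do not differ in one place alone, so they offer no direct guide to the effect of such a change. With only the drawn configuration altered, no step beyond the scatter is expected in this assay, and no firm direction can be given. The estimated step is a 1.2-fold lower number from compound 2 to compound 3 (0.07 log units; within the scatter). For compound 3 the expected value is 650 ng.h/mL, with an estimated range from 280 ng.h/mL to 1500 ng.h/mL.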

Compound 3, area under the concentration-time curve: 457 ng.h/mL
For compound 3 the middle estimate is 1.4-fold (0.15 log units) above the measured one, and the stated range covers the measured number.
By their numbers in this assay, from the lowest: compounds 1, 3 and 2 (each within the scatter of the next, the first and the last beyond it).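

The stereocentre at the saturated ring carbon can now be read on its own: compound 1 and compound 2 differ in more than one place, so they could not show what this single change does. Drawing the centre S rather than R gives a 1.7-fold lower number from compound 2 to compound 3 (0.22 log units; within the scatter) in this assay and so does not separate the two compounds beyond the usual scatter. Oral exposure at this dose therefore shows no clear dependence on the configuration at this carbon, and the comparison is a clean one because nothing else changes: the fact that compounds 2 and 3 differ only in the configuration as drawn

What the compounds shown leave open is how exposure would respond if a methoxy group or an amine took the place of the hydroxyl at this saturated ring carbon. From the compounds shown here alone, whether the two configurations would stay this close at another dose or by another route also remains open.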